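A few compounds are considered here, and "the series" means these few. Any claim that something is new, unique, unknown or untested is made for them only; others in the source may bear on it.

In a functional assay (trachea) with Cavia porcellus as the target (a lower number here means that less compound is needed, a higher number that more compound is needed for the effect), compound 1 (`CCCn1c(=O)n(CC)c(=O)c2[nH]cnc21`) gives 1300 nM and compound 2 (`C=CCCn1cnc2c1c(=O)n(C)c(=O)n2CCC`) gives 16800 nM as the higher of the two numbers, beyond the scatter. Compound 3 (`CCCn1c(=O)n(C)c(=O)c2c1ncn2CCC#N`), set against compound 2, carries cyano in place of vinyl on a saturated chain carbon, two bonds along the chain from an aromatic nitrogen. Among the measured compounds shown here, no measured step covers this change, so the expectation is a loose one. With compound 2 at 16800 nM as the top of the two measured numbers, a modest move to a lower number in this assay is expected rather than a further rise. The expected size is a 2.4-fold lower number from compound 2 to compound 3 (0.38 log units; beyond the scatter) and it carries wide uncertainty. For compound 3 the estimate is 7000 nM with an expected range from 1800 nM to 25000 nM in this read-out.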

Compound 3, half-maximal effective concentration: 27600 nM
Estimate against measurement, compound 3: 3.9-fold (0.60 log units) below, and the stated range ends below it.
By their numbers in this assay, from the lowest: compound 1; then compounds 2 and 3 (each within the scatter of the next).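

In this assay, cyano in place of vinyl on a saturated chain carbon, two bonds along the chain from an aromatic nitrogen, gives a 1.6-fold higher number from compound 2 to compound 3 (0.22 log units; within the scatter), so but-3-en-1-yl and 2-cyanoethyl cannot be told apart at this position. The entering group brings a triple bond and a hydrogen-bond acceptor, the leaving group a double bond and no such acceptor, and the read-out does not separate the two. No measured evidence bears on this result.

As far as these compounds go, this single step gives no general rule for the position, and it stays open whether other groups would also remain within the scatter of compound 2. An amine or a carboxylic acid in place of vinyl on the same saturated chain carbon would test this, as would a longer chain.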